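Working notes: a configuration change from compound 1 to compound 3

The source may hold more compounds than are shown below. What is called first, only, known or untested is meant among the compounds shown, and "the series" means these compounds.

Compound 1 `COc1cc(C[C@@H]2CO[C@@H](c3cc(OC)c(O)c(OC)c3)[C@@H]2CO[C@@H]2O[C@@H](C)[C@H](O)[C@@H](O)[C@H]2O)cc(OC)c1O` has been run in a functional assay on A549 cells (Homo sapiens) for cytotoxicity, read by sulforhodamine B assay; a lower number here means a stronger inhibitor, a higher number a weaker inhibitor. In this assay compound 1 gives > 10000 nM, which is a limit of the measurement rather than a number. Compound 2 `COc1cc(C[C@@H]2CO[C@@H](c3ccc(O)c(OC)c3)[C@@H]2CO[C@@H]2O[C@@H](C)[C@H](O)[C@@H](O)[C@H]2O)ccc1O` has also been run. In this assay compound 2 gives > 10000 nM, again a limit and not a number. For the measured compounds named here, both known values thus sit at the same point, (the limit of > 10000 nM in this assay, at which 2 of the 2 values shown sit), so compound 1 cannot be placed on a scale: no measured compound here has a numerical read-out, and no step between measured compounds exists.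

Compound 3 `COc1cc(C[C@H]2CO[C@@H](c3cc(OC)c(O)c(OC)c3)[C@H]2CO[C@@H]2O[C@@H](C)[C@H](O)[C@@H](O)[C@H]2O)cc(OC)c1O` is the compound still to be measured. Its difference from compound 1 is the two compounds have the same atoms and bonds and differ only in configuration as drawn: 2 of 8 stereo elements differ; a stereocentre at a saturated ring carbon is drawn S in compound 1 and R in compound 3; a stereocentre at a saturated ring carbon is drawn S in compound 1 and R in compound 3. Nothing leaves and nothing enters; only the configuration at two saturated ring carbons is changed. Going by the values given here, with both known values being limits, there is no measured step to give a direction. The expectation in this assay is no change beyond the scatter, most probably a limit once more. Compound 3 is expected to give 10000 nM, with a range from 3000 nM to 30000 nM. This estimate implies a step of a number no higher from compound 1 to compound 3 (the limit leaves the size open), expected to be negligible.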

Compound 3, half-maximal inhibitory concentration: > 10000 nM
Compound 3 was reported as a limit; the forecaster's own chance of this, stated with the estimate: 85%; the middle value sits exactly at the limit.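

In this assay compound 3 gives > 10000 nM, a limit and not a number. With compound 1 also at a limit, no step can be read between compound 1 and compound 3: the limit of > 10000 nM in this assay, at which 3 of the 3 values shown sit.

The compounds shown leave open whether the configuration at the two saturated ring carbons has any bearing on the read-out in this assay.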